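Trimming the sulfur side chain of a pyrazolopyrimidine growth inhibitor

The source may report more compounds than this note shows. Statements on the series, on what has been measured and on what is new or still open speak of the compounds shown alone.

Compound 1 `CC(C)c1n[nH]c2c(NCc3ccc(-c4ccccn4)cc3)nc(SCC3CNC(=O)O3)nc12`: 80 nM
Compound 2 `CC(C)c1n[nH]c2c(NCc3ccc(-c4ccccn4)cc3)nc(SCCNC(=N)N)nc12`: 390 nM

Among the two measured compounds in a functional assay on HT cells (Homo sapiens) for antiproliferative activity, read by fluorescence, with a stated time of 72 h (on this read-out higher numbers stand for weaker inhibition of growth and lower numbers for stronger inhibition of growth), compound 1 gives the lowest number, and its nearest neighbour is compound 2, which lies a 4.9-fold higher number from compound 1 to compound 2 (0.69 log units; beyond the scatter) away. For the measured compounds named here, that one step is the only guide here: swapping the five-membered ring for an open chain on the same carbon weakened growth inhibition by a modest amount.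

Compound 3 `CC(C)c1n[nH]c2c(NCc3ccc(-c4ccccn4)cc3)nc(S)nc12` goes further. Its difference from compound 1 is hydrogen in place of (2-oxo-1,3-oxazolidin-5-yl)methyl on a sulfur, so the whole (2-oxo-1,3-oxazolidin-5-yl)methyl group is gone and only a sulfanyl remains on the shared core. Going by the values given here, no measured pair removes this group outright, so the expectation rests on the single step above, which already points toward weaker inhibition when the ring is altered. For compound 3 a further loss is therefore expected, estimated as a 13-fold higher number from compound 1 to compound 3 (1.10 log units; beyond the scatter). The expected value for compound 3 is 1000 nM, within a range of 200 nM to 5000 nM.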

Compound 3, concentration for 50% growth inhibition: 2760 nM
Compound 3: the middle estimate sits 2.8-fold (0.44 log units) below what was measured, within the range that was stated.
By their numbers in this assay, from the lowest: compound 1; then compound 2; then compound 3.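

Cutting the side chain back to a bare sulfanyl gives the largest change seen so far in this assay (a 35-fold higher number from compound 1 to compound 3 (1.54 log units; beyond the scatter)), so growth inhibition here depends strongly on what sits on this sulfur. The open chain of compound 2 also does better than hydrogen (a 7.1-fold higher number from compound 2 to compound 3 (0.85 log units; beyond the scatter)), which shows that the benefit is not confined to the five-membered ring of compound 1. Nothing measured here explains why either side chain gives stronger inhibition than hydrogen.

The compounds shown leave open how much of the benefit needs a particular group and how much needs only some chain on the sulfur. A small methyl, a plain propyl chain or a simple primary amine at the end of a chain would help to separate these possibilities.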